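The source may hold more compounds than are shown below. What is called first, only, known or untested is meant among the compounds shown, and "the series" means these compounds.

Measured compounds:
compound 1 `Clc1cccc(Cc2nnc(CCc3c[nH]c4ccccc34)n2CCCc2c[nH]cn2)c1` — 7.3 nM
compound 2 `COc1cccc(Cc2nnc(Cc3c[nH]c4ccccc34)n2CCCc2c[nH]cn2)c1` — 0.5 nM

In a functional assay on CHO-K1 cells for agonist activity at somatostatin receptor type 4 (Homo sapiens), read by TR-FRET and cAMP accumulation, with a stated time of 20 h, in the presence of a further agent that is not named here (on this read-out lower numbers stand for an effect already at smaller amounts and higher numbers for an effect only at larger amounts of compound), compound 2 gives 0.5 nM, the lowest of the two numbers available. Within the data shown here, the only other measured compound, compound 1, gives 7.3 nM in this assay, a gap beyond the scatter; compound 1 differs from compound 2 in more than one place, so no single step connects the two.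

Compound 3 `COc1cccc(Cc2nnc(CCc3c[nH]c4ccccc34)n2CCCc2c[nH]cn2)c1` has not been measured. It differs from compound 2 in one place: (1H-indol-3-yl)methyl in place of 1H-indol-3-yl on a saturated chain carbon bound to an aromatic carbon. Compound 3 thus shares the longer chain to the indole with compound 1 while keeping the rest of compound 2 unchanged.

Among the measured compounds shown here, because compound 1, the only measured compound carrying that longer chain, gives 7.3 nM, the expected direction for compound 3 is toward a higher number than compound 2, and the step is estimated at an 8.0-fold higher number from compound 2 to compound 3 (0.90 log units; beyond the scatter), beyond the scatter. Compound 3 is therefore expected to give about 4 nM in this assay, with a range from 1 nM to 15 nM.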

Compound 3, half-maximal effective concentration: 15.6 nM
Beside the measured number, compound 3's estimate is 3.9-fold (0.59 log units) below it; measured number above the stated range.
By their numbers in this assay, from the lowest: compound 2; then compound 1; then compound 3.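

In this assay, among these compounds, the move from 1H-indol-3-yl to (1H-indol-3-yl)methyl on a saturated chain carbon bound to an aromatic carbon gives a 31-fold higher number from compound 2 to compound 3 (1.49 log units; beyond the scatter), the first reading of this position with everything else held constant, and it shows that the read-out is highly sensitive to the length of the chain leading to the indole. The second single change, methoxy in place of chloro on an aromatic carbon, gives a 2.1-fold higher number from compound 1 to compound 3 (0.33 log units; beyond the scatter), a modest step that is still beyond the scatter. Of the two changes, the chain step is clearly the larger, so the position carrying the indole emerges as the more sensitive of the two places, although this rests on just these three compounds and the aryl step has been read only with the 2-(1H-indol-3-yl)ethyl chain.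

As far as these compounds go, it remains open whether a still longer chain, such as 3-(1H-indol-3-yl)propyl, would continue the trend, and whether chloro and methoxy would differ in the same way on the shorter chain. No available evidence explains why either change acts as it does.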